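From Phenyl to 4-Chlorophenyl: A Small Step Expected

A few compounds are considered here, and "the series" means these few. Any claim that something is new, unique, unknown or untested is made for them only; others in the source may bear on it.

Measured in a functional assay on the whole organism (Hindlimb, strain albino) with Mus musculus as the target, in the maximal electroshock model, with a stated time of 0.5 h; on this read-out lower numbers stand for an effect already at smaller amounts and higher numbers for an effect only at larger amounts of compound:
Compound 1 `Cc1ccc2nc(NC(=O)/C=C/c3ccc(O)cc3)sc2c1`: 271 umol/kg
Compound 2 `Cc1ccc2nc(NC(=O)/C=C/c3ccccc3)sc2c1`: 380 umol/kg

Compound 2 at 380 umol/kg stands within the scatter of compound 1. Compound 3 `Cc1ccc2nc(NC(=O)/C=C/c3ccc(Cl)cc3)sc2c1` carries chloro in place of hydrogen on an aromatic carbon of compound 2, para to a large group: chloro in place of hydrogen on an aromatic carbon. Going by the values given here, the only measured step that bears on this change, hydrogen in place of hydroxy, is a 1.4-fold higher number from compound 1 to compound 2 (0.15 log units; within the scatter), so no step beyond the scatter is expected in this assay. The expected step is a 1.3-fold lower number from compound 2 to compound 3 (0.10 log units; within the scatter). The estimate for compound 3 is 300 umol/kg, with an expected range from 130 umol/kg to 650 umol/kg.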

Compound 3, dose for half-maximal effect: 152 umol/kg
The estimate for compound 3 lay 2.0-fold (0.30 log units) above the measured number; low and high end bracket the measured number.
By their numbers in this assay, from the lowest: compounds 3, 1 and 2 (each within the scatter of the next, the first and the last beyond it).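

In this assay, going by these compounds alone, the 4-chlorophenyl group gives the first step that lies beyond the scatter, with chloro in place of hydrogen para to a large group (a 2.5-fold lower number from compound 2 to compound 3 (0.40 log units; beyond the scatter)). Chloro in place of hydroxy at the same place stays within the scatter (a 1.8-fold lower number from compound 1 to compound 3 (0.25 log units; within the scatter)), so only the step from the unsubstituted phenyl can be read as a real difference. Nothing available explains why this step has the size it has.

On these data alone, what a methoxy group, a fluoro group or an amine would give at this place remains open. So does whether the gain from chloro would persist with a different group on the shared core.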